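A few compounds are considered here, and "the series" means these few. Any claim that something is new, unique, unknown or untested is made for them only; others in the source may bear on it.

Measured so far in a functional assay on T47D cells (Homo sapiens) for antiproliferative activity, read by sulforhodamine B assay, with a stated time of 48 h; a lower number here means a stronger inhibitor of growth, a higher number a weaker inhibitor of growth:
compound 1 `COc1ccc(OC)c(/C=C/c2nnc(Nc3ccc(Cl)cc3)o2)c1` gives 2540 nM
compound 2 `COc1ccc(OC)c(/C=C/C(=O)N/N=C/c2ccc(Cl)cc2)c1` gives 160 nM

Of these two, compound 2 stands at the lower number, and the gap to compound 1 is well beyond the usual scatter, so compound 2 is the stronger growth inhibitor of the pair. Within the data shown here, only two compounds have been measured, and they differ in more than one place, so no single step between measured compounds can be read from them.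

The next compound keeps the core of compound 2 and removes one substituent: compound 3 `COc1ccc(OC)c(/C=C/C(=O)N/N=C/c2ccccc2)c1`. The change is hydrogen in place of chloro on an aromatic carbon; the site is on an aromatic carbon of a six-membered aromatic ring of carbon only, para to a large group. Nothing in the measured data shows what a change of this kind does in this assay, so the expectation rests on the general observation that the loss of one small atom from an outer ring usually shifts the number only modestly, in either direction. The expected step from compound 2 to compound 3 is a 1.9-fold higher number from compound 2 to compound 3 (0.27 log units; within the scatter), a small weakening that may lie within the scatter. Compound 3 is therefore expected to give about 300 nM, with a likely range from 120 nM to 800 nM.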

Compound 3, concentration for 50% growth inhibition: 4860 nM
The estimate for compound 3 lay 16-fold (1.21 log units) below the measured number; measured number above the stated range.
By their numbers in this assay, from the lowest: compound 2; then compounds 1 and 3 (each within the scatter of the next).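

In this assay, the chloro group on the outer ring proves to matter far more than its size alone might suggest: replacing this one heavy atom with hydrogen, on an aromatic carbon para to a large group, gives a 30-fold higher number from compound 2 to compound 3 (1.48 log units; beyond the scatter). Among these compounds, this is the first step that changes only one place, so it is the first direct reading of any single position, and within this pair the 4-chlorophenyl group gives much stronger growth inhibition than phenyl with the rest of the molecule unchanged. No measured information explains why so small a change has so large an effect.

As far as these compounds go, it remains open whether chlorine itself is needed or whether another group at the same place would serve as well; a fluoro, methyl, methoxy or trifluoromethyl group there, each read against both compound 2 and compound 3, would begin to answer that. Also unresolved is whether chloro elsewhere on that ring would keep the activity, and whether the same change would have a similar effect on a different core, such as that of compound 1.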